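Swapping a Pyridine for a Cyanophenyl on the Benzyl Arm

The source may hold more compounds than are shown below. What is called first, only, known or untested is meant among the compounds shown, and "the series" means these compounds.

Three compounds sharing one core have been compared in a functional assay on a cell-free system (plasma, Oryctolagus cuniculus) for inhibition, with stated times of 5 min, 1 min and 6 min; on this read-out higher numbers stand for weaker inhibition and lower numbers for stronger inhibition. Compound 1 `CCOC(=O)c1c(C)nc(-c2ccccc2C#N)n1OC` gives 14900 nM, compound 2 `CCOC(=O)c1c(C)nc(-c2ccc(C#N)cc2)n1OC` gives 13400 nM, and compound 3 `CCOC(=O)c1c(C)nc(-c2cccc(C#N)c2)n1OCc1ccncc1` gives 6200 nM, the lowest of the three numbers; compound 2 lies nearest and compound 1 furthest, both beyond the scatter. Compound 4 `CCOC(=O)c1c(C)nc(-c2cccc(C#N)c2)n1OCc1ccc(C#N)cc1` has not been measured. It differs from compound 3 in one place: 4-cyanophenyl in place of pyridin-4-yl on a saturated chain carbon bound to an oxygen on an aromatic ring. Going by the values given here, no pair of measured compounds tests this exchange, so its direction is open. A modest shift in either sense, possibly none beyond the scatter, is expected. For compound 4 in this assay the estimate is 5500 nM, from 2000 nM to 15000 nM, meaning an expected step of a 1.1-fold lower number from compound 3 to compound 4 (0.05 log units; within the scatter).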

Compound 4, half-maximal inhibitory concentration: 4240 nM
Estimate against measurement, compound 4: 1.3-fold (0.11 log units) above, and the stated range covers the measured number.
By their numbers in this assay, from the lowest: compounds 4 and 3 (each within the scatter of the next); then compounds 2 and 1 (each within the scatter of the next).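

At this position, on a saturated chain carbon bound to an oxygen on an aromatic ring, 4-cyanophenyl in place of pyridin-4-yl gives a 1.5-fold lower number from compound 3 to compound 4 (0.17 log units; within the scatter) in this assay. Inhibition at this level therefore does not depend on the ring nitrogen of pyridin-4-yl, and the added nitrile brings no change that can be told from the scatter. No available evidence explains this outcome. On these data alone, what remains open is how plain phenyl, a carboxylic acid or an amine would read out on the same carbon.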